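The source may hold more compounds than are shown below. What is called first, only, known or untested is meant among the compounds shown, and "the series" means these compounds.

In an ADME assay for permeability, using PAMPA, with a stated time of 30 min, at pH 7.4 (a higher number here means that the compound crosses the layer faster, a lower number that the compound crosses the layer more slowly), compound 2 `c1coc(CNCCCNc2ccnc3cc(C4CCCCC4)ccc23)c1` gives 23 10^-6 cm/s. Its nearest measured neighbour, compound 1 `CC(C)CCc1ccc2c(NCCCNCc3ccco3)ccnc2c1`, gives 23 10^-6 cm/s in this assay, and no change at the digits printed from compound 1 to compound 2 (within the scatter). Compound 3 `CCC(CC)c1ccc2c(NCCCNCc3ccco3)ccnc2c1` differs from compound 2 by pentan-3-yl in place of cyclohexyl on an aromatic carbon. Among the compounds with values here, the one measured step bearing on this, which also exchanged one carbon-only group for another on an aromatic carbon, produced no shift, so in this assay the present exchange is likewise expected to give no step beyond the scatter, that is no change at the digits printed from compound 2 to compound 3 (within the scatter). Compound 3 is therefore estimated at 23 10^-6 cm/s, with a range from 14 10^-6 cm/s to 36 10^-6 cm/s.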

Compound 3, apparent permeability in the ADME assay: 23 10^-6 cm/s
For compound 3 middle estimate and measured number coincide at the digits printed; measured number inside the range.
By their numbers in the ADME assay, from the lowest: compounds 1, 2 and 3 (each within the scatter of the next).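

In the ADME assay, opening the six-membered ring of cyclohexyl to pentan-3-yl gives no change at the digits printed from compound 2 to compound 3 (within the scatter) and exchanging isopentyl for pentan-3-yl gives no change at the digits printed from compound 1 to compound 3 (within the scatter), so a ring and two branched chains on this aromatic carbon stand level. In a physicochemical assay for solubility, with a stated time of 18 h, at pH 7.4 (a higher number here means a more soluble compound, a lower number a less soluble compound), compound 2 gives 4200 nM and compound 3 gives 4200 nM, which is no change at the digits printed from compound 2 to compound 3 (within the scatter), so the ring-to-chain change also leaves this second read-out level. Nothing available explains why these groups read alike. As far as these compounds go, all three groups contain carbon only, so what an amine or a carboxylic acid on this aromatic carbon would do remains open.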